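A few compounds are considered here, and "the series" means these few. Any claim that something is new, unique, unknown or untested is made for them only; others in the source may bear on it.

Measured so far in an ADME assay on HEK293 cells (Homo sapiens) for cytotoxicity, read by WST assay; a higher number here means that more compound is tolerated, a lower number that less compound is tolerated:
- compound 1 `O=C(OCc1ccc(B(O)O)cc1)c1cc(C(F)(F)F)cc(C(F)(F)F)c1`: 49000 nM
- compound 2 `NC(=O)c1ccc(COC(=O)c2cc(C(F)(F)F)cc(C(F)(F)F)c2)cc1`: > 100000 nM (a limit of the assay, not a number)
- compound 3 `CC(C)(C)c1ccc(C(=O)OCc2ccc(C=O)cc2)cc1`: 63000 nM

Compound 2 stands at the limit of > 100000 nM in this assay, at which 1 of the 3 values shown sits, so its place is known only as a limit. The next compound is compound 4 `O=Cc1ccc(COC(=O)c2cc(C(F)(F)F)cc(C(F)(F)F)c2)cc1`, and the change is hydrogen in place of amino on a carbonyl carbon, which turns 4-carbamoylphenyl into 4-formylphenyl.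

For the measured compounds named here, one measured step bears on this, since it also swaps a single group on the same core: an at least 2.0-fold higher number from compound 1 to compound 2 (0.30 log units; that floor lies within the scatter). With only a floor, and that floor within the scatter, this step sets no firm size. The number for compound 1 is still useful, as compound 1 gives 49000 nM on the core of compound 4. Compound 3 carries the same formyl group on another core, and compound 3 gives 63000 nM. These two numbers lie close together, and they suggest that compound 4 will land near them, with somewhat less compound tolerated in this assay. The expected change is an at least 1.8-fold lower number from compound 2 to compound 4 (0.25 log units; that floor lies within the scatter). Compound 4 is estimated at 55000 nM, with an expected range of 20000 nM to 100000 nM.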

Compound 4, half-maximal cytotoxic concentration: > 100000 nM
Compound 4 ended at the assay's limit; the forecaster's own chance of this, stated with the estimate: 20%; middle value at least 1.8-fold (0.25 log units) from the limit.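

In this assay compound 4 gives > 100000 nM, which is a limit of the assay and not a number. The step between compound 2 and compound 4 therefore cannot be read, because both compounds sit at the same limit: the limit of > 100000 nM in this assay, at which 2 of the 4 values shown sit.

Set against the boronic acid on the shared core, the result is an at least 2.0-fold higher number from compound 1 to compound 4 (0.30 log units; that floor lies within the scatter), so the formyl group reads the same way in this comparison as the carbamoyl group did, and the amino group is not needed for a compound on this core to reach the limit.

Where compound 2 and compound 4 truly stand relative to each other remains open, so no order between carbamoyl and formyl can be given. Also open, going by these compounds, is whether another group in the same place on the shared core, such as a carboxylic acid, a nitrile or an amine, would reach this limit as well or would give a number that can be read.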